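Para-substituted benzyl amides: next step in the series

This account rests on a few compounds, and the source may have more. Where it says the series, first, only, none or still open, it means among the compounds named here.

Compound 1 `COC(=O)/C=C/c1cccc(N(Cc2ccc(-c3ccc(C(C)(C)C)cc3)cc2)C(=O)C2CCCCC2)c1`: 132 nM
Compound 2 `COC(=O)/C=C/c1cccc(NC(=O)C2CCCCC2)c1`: > 1000 nM
Compound 3 `COC(=O)/C=C/c1cccc(N(Cc2ccccc2)C(=O)C2CCCCC2)c1`: > 1000 nM

In an assay on isolated protein with Bile acid receptor (Homo sapiens) as the target (on this read-out higher numbers stand for an effect only at larger amounts of compound and lower numbers for an effect already at smaller amounts), compound 1 gives 132 nM. For compound 2 the value > 1000 nM is a limit of the assay and not a number. For compound 3 the value > 1000 nM is likewise a limit. For the measured compounds named here, two of the three values so far sit at the limit of > 1000 nM in this assay, at which 2 of the 3 values shown sit, so compound 3 stands at the weak end of what has been read, without a number of its own.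

The step from compound 3 to compound 4 `COC(=O)/C=C/c1cccc(N(Cc2ccc(/C=C/c3c(Cl)cccc3Cl)cc2)C(=O)C2CCCCC2)c1` is 2-(2,6-dichlorophenyl)ethenyl in place of hydrogen on an aromatic carbon.

Going by the values given here, the one measured step that speaks to this position is an at least 7.5-fold higher number from compound 1 to compound 3 (0.87 log units; beyond the scatter), where the large group leaves the same aromatic carbon and the number climbs out of the readable range. Compound 4 restores a large group at that spot, a 2-(2,6-dichlorophenyl)ethenyl in place of hydrogen. The step from compound 2 to compound 3, a step that the two limits leave unreadable from compound 2 to compound 3, gives no guidance, as both ends are limits.

By analogy with compound 1, a reversal of the loss seen in an at least 7.5-fold higher number from compound 1 to compound 3 (0.87 log units; beyond the scatter) is expected, so compound 4 is estimated to reach 200 nM (range 50 nM to 1000 nM). The expected step is an at least 5.0-fold lower number from compound 3 to compound 4 (0.69 log units; beyond the scatter).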

Compound 4, half-maximal effective concentration: 150 nM
For compound 4 the middle estimate is 1.3-fold (0.12 log units) above the measured one; the range from low to high includes it.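

In this assay, 2-(2,6-dichlorophenyl)ethenyl in place of hydrogen on this aromatic carbon gives an at least 6.6-fold lower number from compound 3 to compound 4 (0.82 log units; beyond the scatter), so the gain at this position is no longer tied to 4-(tert-butyl)phenyl alone. Exchanging one large group for the other gives a 1.1-fold higher number from compound 1 to compound 4 (0.06 log units; within the scatter), so the two groups cannot be told apart in this assay, even though one carries a double bond and two chlorine atoms and the other does not. The first of these steps has only one firm end, since the reading for compound 3 is a limit of the assay and not a number: the limit of > 1000 nM in this assay, at which 2 of the 4 values shown sit.

The compounds shown leave open whether the six-membered aromatic ring of the entering group is needed at all, a question that an unbranched alkyl chain or an amine on the same aromatic carbon would address, and what the two chlorine atoms contribute on their own. Also open, from the compounds shown here alone, is whether the methyl ester shared by all four compounds can give way to a carboxylic acid without loss in this assay.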